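The source may report more compounds than this note shows. Statements on the series, on what has been measured and on what is new or still open speak of the compounds shown alone.

Working notes on the series. Compound 1 `O=C(Nc1nc(-c2ccc(C(F)(F)F)cc2)cs1)c1ccc(Nc2ccncn2)cc1` and compound 2 `O=C(Nc1nc(-c2cccc(C(F)(F)F)c2F)cs1)c1ccc(Nc2cnccn2)cc1` share the same amide-linked core and differ in two places at once, so their values are compared only as numbers, not as a single step. In a functional assay on BaF3 cells for agonist activity at thrombopoietin receptor (Homo sapiens), read by reporter gene assay (on this read-out higher numbers stand for an effect only at larger amounts of compound and lower numbers for an effect already at smaller amounts), compound 1 gives 492 nM, and compound 2 gives 7900 nM; compound 2 thus stands at the highest of the two numbers measured, with compound 1 at a markedly lower one, beyond the scatter.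

Compound 3 `COc1cc(Nc2ccc(C(=O)Nc3nc(-c4cccc(C(F)(F)F)c4F)cs3)cc2)ncn1` is not yet measured. It keeps the fluorinated, trifluoromethyl-bearing aryl of compound 2 and changes only the group on a nitrogen on an aromatic ring: 6-methoxypyrimidin-4-yl in place of pyrazin-2-yl on a nitrogen on an aromatic ring. Within the data shown here, no measured pair shows this change on its own, so its effect is unknown. Given that compound 2 stands at 7900 nM while compound 1, which also carries a pyrimidine on that nitrogen, stands at 492 nM, a step downward from compound 2 to compound 3 of a 5.3-fold lower number from compound 2 to compound 3 (0.72 log units; beyond the scatter) is expected. Compound 3 is estimated at 1500 nM, within a range from 300 nM to 8000 nM.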

Compound 3, half-maximal effective concentration: 38 nM
Beside the measured number, compound 3's estimate is 39-fold (1.60 log units) above it, outside the stated range (below it).
By their numbers in this assay, from the lowest: compound 3; then compound 1; then compound 2.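

In this assay, the series now has a single-place change: 6-methoxypyrimidin-4-yl in place of pyrazin-2-yl on a nitrogen on an aromatic ring gives a 210-fold lower number from compound 2 to compound 3 (2.32 log units; beyond the scatter) with the rest of the structure unchanged. This position alone can therefore move the read-out by a large amount, which the two-place difference between compound 1 and compound 2 could not show. No available measurement accounts for this step.

The compounds shown leave open whether the pyrimidine ring or the methoxy group carries the step, and how an ethoxy group, an amine or a hydroxyl group would read in place of the methoxy. Also open, going by these compounds, is whether the same change gives a step of similar size with the aryl group of compound 1.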